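The source may hold more compounds than are shown below. What is called first, only, known or untested is meant among the compounds shown, and "the series" means these compounds.

Measured so far in an assay on isolated protein for inhibition of serine/threonine-protein kinase TNNI3K (Homo sapiens); a higher number here means a weaker inhibitor, a lower number a stronger inhibitor:
compound 1, `CNc1cc(Oc2ccc(NC(=O)Nc3cccc(C)c3)cc2)ncn1`: 1260 nM
compound 2, `O=C(Nc1ccc(Oc2cc(O)ncn2)cc1)Nc1cccc(C(F)(F)F)c1`: 3200 nM

Compound 2 holds the highest of the two numbers; compound 1 sits lower than compound 2, a gap beyond the usual scatter. Compound 3, `CC(C)Nc1cc(Oc2ccc(NC(=O)Nc3cccc(C(F)(F)F)c3)cc2)ncn1`, has not yet been measured. It differs from compound 2 as follows: isopropylamino in place of hydroxy on an aromatic carbon. Because compound 2 gives 3200 nM and compound 1 gives 1260 nM, a step in this assay toward a lower number is expected, of modest size, likely beyond the scatter. The step from compound 2 to compound 3 is estimated at a 4.0-fold lower number from compound 2 to compound 3 (0.60 log units; beyond the scatter). Compound 3 is expected at 800 nM, within 250 nM to 2500 nM.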

Compound 3, half-maximal inhibitory concentration: 40 nM
Compound 3: the middle estimate sits 20-fold (1.30 log units) above what was measured; the whole stated range lies above it.
By their numbers in this assay, from the lowest: compound 3; then compound 1; then compound 2.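

In this assay the swap of hydroxy for isopropylamino gives an 80-fold lower number from compound 2 to compound 3 (1.90 log units; beyond the scatter) with the rest of the structure unchanged. Going by these compounds alone, this position on the shared core therefore has a large bearing on the number, a fact not visible from the earlier compounds alone. Hydroxy and isopropylamino carry the same count of hydrogen-bond donors and acceptors, so that count does not track the step.

Going by these compounds, whether the drop needs the branched isopropyl group, or would also appear with an unsubstituted amine, a cyclopropylamino group or a longer chain here, stays open. Nothing at hand says why the step is so large.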